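Swapping the Aryl Group at the Quaternary Ring Carbon

The source may report more compounds than this note shows. Statements on the series, on what has been measured and on what is new or still open speak of the compounds shown alone.

Measured compounds:
- compound 1 `O=C1Nc2c(ccc(F)c2F)C1(c1ccc(O)cc1)c1ccc(F)cc1`: 2.6 nM in a functional assay on MCF7 cells (Homo sapiens) for cytotoxicity, read by WST assay, with a stated time of 72 h; on this read-out lower numbers stand for stronger inhibition and higher numbers for weaker inhibition
- compound 2 `CCCCCOc1ccc(C2(c3ccc(O)cc3)C(=O)Nc3c2ccc(F)c3F)cc1`: compound 2 gives > 1000 nM, a limit of this assay, not a number.

For the measured compounds named here, compound 1 stands alone as the only compound with an actual number in this assay; the other entry is a limit (the limit of > 1000 nM in this assay, at which 1 of the 2 values shown sits). Going by the values given here, the one measured step, an at least 380-fold higher number from compound 1 to compound 2 (2.58 log units; beyond the scatter), puts pentyloxy in place of fluoro on an aromatic carbon and is large.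

Compound 3 `O=C1Nc2c(ccc(F)c2F)C1(c1ccc(O)cc1)c1cccs1` differs from compound 1 by thiophen-2-yl in place of 4-fluorophenyl on a saturated ring carbon. This change touches a different place and different groups than the measured step, so that step bears only loosely on it; it does show the shared core tolerating little at one position, but gives no direct guide here. A step within the scatter, or a modest weakening, is expected for compound 3. Compound 3 is therefore estimated at 6 nM, within 1.5 nM to 25 nM, a step of a 2.3-fold higher number from compound 1 to compound 3 (0.36 log units; beyond the scatter).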

Compound 3, half-maximal inhibitory concentration: 82 nM
Compound 3: the middle estimate sits 14-fold (1.14 log units) below what was measured; measured number outside the range, above it.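

In this assay, thiophen-2-yl on the saturated ring carbon gives a 32-fold higher number from compound 1 to compound 3 (1.50 log units; beyond the scatter) and so the aryl group at this place cannot be exchanged freely, even for another aromatic ring. The earlier step changed only the group carried on an aromatic carbon, whereas this one replaces the ring itself, and a five-membered aromatic ring with 1 hetero atom proves a poor stand-in for the six-membered aromatic ring of carbon only in compound 1. Nothing shown here accounts for the size of this step.

The compounds shown leave open whether the step follows from the ring size, the sulfur or the loss of the fluoro. From the compounds shown here alone, how a plain phenyl, a pyridyl or a furan-2-yl group would fare at this place also remains open.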